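Swapping a Nitrophenyl for a Chlorobenzothiophene Arm

The source may hold more compounds than are shown below. What is called first, only, known or untested is meant among the compounds shown, and "the series" means these compounds.

Compound 3 `Cc1cc(N2CC[C@@H](C)[C@@H](N(C)c3ncnc4[nH]ccc34)C2)n2nc(SCc3ccc([N+](=O)[O-])cc3)nc2n1` was tested in a toxicity assay on GES1 cells (Homo sapiens) for inhibition, read by MTT assay, with a stated time of 72 h (on this read-out higher numbers stand for weaker inhibition and lower numbers for stronger inhibition), where compound 3 gives 36600 nM. Two other compounds share its core. Compound 1 `Cc1cc(N2CC[C@@H](C)[C@@H](N(C)c3ncnc4[nH]ccc34)C2)n2ncnc2n1` gives 57900 nM, and compound 2 `Cc1cc(N2CC[C@@H](C)[C@@H](N(C)c3ncnc4[nH]ccc34)C2)n2nc(SCCc3ccccc3)nc2n1` gives 66200 nM. Compound 3 has the lowest of the three numbers, but the distances are small: the step of a 1.6-fold lower number from compound 1 to compound 3 (0.20 log units; within the scatter) and the step of a 1.8-fold lower number from compound 2 to compound 3 (0.26 log units; within the scatter) both fall within the scatter, as does a 1.1-fold higher number from compound 1 to compound 2 (0.06 log units; within the scatter). None of these changes on the sulfur-bearing arm has moved the read-out in a way that can be trusted.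

Compound 4 `Cc1cc(N2CC[C@@H](C)[C@@H](N(C)c3ncnc4[nH]ccc34)C2)n2nc(SCc3csc4ccc(Cl)cc34)nc2n1` has not yet been measured. It differs from compound 3 in one place: 5-chloro-1-benzothiophen-3-yl in place of 4-nitrophenyl on a saturated chain carbon bound to a sulfur. Among the measured compounds shown here, the step from compound 2 to compound 3 is the only measured one that changes the group on this same saturated chain carbon bound to a sulfur, and it stayed within the scatter. The two steps from compound 1, which add the whole arm, are also within the scatter. A further change at this position is therefore expected to give only a small step, a 1.1-fold higher number from compound 3 to compound 4 (0.04 log units; within the scatter), in no firm direction. Compound 4 is expected to give about 40000 nM, with a likely range from 15000 nM to 100000 nM.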

Compound 4, half-maximal inhibitory concentration: > 100000 nM
Compound 4: no number, only a limit (the forecaster's own chance of this, stated with the estimate: 15%); at least 2.5-fold (0.39 log units) between middle value and limit.
By their numbers in this assay, from the lowest: compounds 3, 1 and 2 (each within the scatter of the next). At a limit, above all of these: compound 4.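

The group on the saturated chain carbon bound to a sulfur can move this read-out after all: an at least 2.7-fold higher number from compound 3 to compound 4 (0.43 log units; beyond the scatter) is the first step among these compounds to pass the scatter, and in this assay it points toward weaker inhibition. From the compounds shown here alone, compound 4 gives no number, only a limit of the assay, so this step is a floor and its true size stays unknown: the limit of > 100000 nM in this assay, at which 1 of the 4 values shown sits. The other two steps, an at least 1.5-fold higher number from compound 2 to compound 4 (0.17 log units; that floor lies within the scatter) and an at least 1.7-fold higher number from compound 1 to compound 4 (0.23 log units; that floor lies within the scatter), cannot be read as real differences, so compound 4 is only firmly separated from compound 3, not from the arm-free compound 1 or from compound 2.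

This change alters several things at once, with the 4-nitrophenyl leaving and the 5-chloro-1-benzothiophen-3-yl entering, so the compounds shown cannot say whether the chlorine, the ring sulfur or the second ring accounts for the step. Also open, going by these compounds, is how a plain 1-benzothiophen-3-yl without chlorine, or an amine or a carboxylic acid on the same saturated chain carbon bound to a sulfur, would read in this assay.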